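Notes on a quinolinylmethoxy oxime-ether series

This account rests on a few compounds, and the source may have more. Where it says the series, first, only, none or still open, it means among the compounds named here.

Two members of this series have numbers. Compound 2 `CCCCC(O/N=C/C(=O)O)c1ccc(OCc2ccc3ccccc3n2)cc1` gives 52 nM in a functional assay for inhibition of Polyunsaturated fatty acid 5-lipoxygenase (Homo sapiens); a higher number here means a weaker inhibitor, a lower number a stronger inhibitor. Compound 1 `O=C(O)c1ccc(/C=N/OC(c2ccc(OCc3ccc4ccccc4n3)cc2)C2CCCCC2)cc1`, which carries a cyclohexyl group and a benzoic acid in place of the glyoxylic acid, gives 31 nM in this assay; the two values lie within the scatter of each other, so neither stands apart.

Compound 3 `CC(C)(CC(O/N=C/C(=O)O)c1ccc(OCc2ccc3ccccc3n2)cc1)c1ccccc1` is not yet measured. It differs from compound 2 in one place: 1-methyl-1-phenylethyl in place of propyl on a saturated chain carbon, two bonds along the chain from an aromatic carbon and an oxygen on an unsaturated carbon. Among the measured compounds shown here, no measured pair shows this change, so its effect in this assay is open. Because compound 1 with its bulky cyclohexyl group still gives 31 nM, a larger group on that chain carbon appears to be tolerated, and the expectation is no step beyond the scatter in either direction. The expected step from compound 2 to compound 3 is a 1.2-fold lower number from compound 2 to compound 3 (0.06 log units; within the scatter). Compound 3 is therefore estimated at 45 nM, within a range of 14 nM to 140 nM.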

Compound 3, half-maximal inhibitory concentration: 10 nM
For compound 3 the middle estimate is 4.5-fold (0.65 log units) above the measured one; the whole stated range lies above it.
By their numbers in this assay, from the lowest: compound 3; then compounds 1 and 2 (each within the scatter of the next).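

Among the compounds shown here, on the saturated chain carbon, two bonds along the chain from an aromatic carbon and an oxygen on an unsaturated carbon, the change from propyl to 1-methyl-1-phenylethyl gives the first single-change step: in this assay it is a 5.2-fold lower number from compound 2 to compound 3 (0.72 log units; beyond the scatter), beyond the scatter. This position therefore accepts 9 heavy atoms and a six-membered aromatic ring in place of 3 carbons, and the number falls rather than merely holding. No measurement here bears on why the number falls.

The compounds shown do not separate the contribution of the phenyl ring from that of the two methyl groups, which a benzyl or a tert-butyl group at this carbon would address. As far as these compounds go, whether the step carries over to a benzoic acid in place of the glyoxylic acid also remains open.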